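This account rests on a few compounds, and the source may have more. Where it says the series, first, only, none or still open, it means among the compounds named here.

In a functional assay on the whole organism (brain) with Mus musculus as the target (a lower number here means that less compound is needed, a higher number that more compound is needed for the effect), three compounds have been measured: compound 1 (`CC(=O)c1ccc(OCCc2c[nH]cn2)cc1`) gives 3.2 mg/kg, compound 2 (`CCC(=O)c1ccc(OCCc2c[nH]cn2)cc1`) gives 0.95 mg/kg, and compound 3 (`Cc1ccc(OCCc2c[nH]cn2)cc1`) gives 2.3 mg/kg. Among the compounds with values here, the step of a 1.4-fold lower number from compound 1 to compound 3 (0.14 log units; within the scatter) lies within the scatter, while the step of a 2.4-fold higher number from compound 2 to compound 3 (0.38 log units; beyond the scatter) goes beyond it, so compound 3 stays close to only one of its two neighbours.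

Compound 4 (`CCCc1ccc(OCCc2c[nH]cn2)cc1`) carries ethyl in place of hydrogen on a saturated chain carbon bound to an aromatic carbon, which turns methyl into propyl: ethyl in place of hydrogen on a saturated chain carbon bound to an aromatic carbon. The nearest measured precedent is the lengthening of acetyl to propanoyl, a modest step of a 3.4-fold lower number from compound 1 to compound 2 (0.53 log units; beyond the scatter). This is a single pair, it involves a carbonyl, and it adds methyl rather than ethyl, so it offers only loose guidance. A modest step towards a lower number in this assay is therefore expected, of somewhat smaller size than that precedent. The estimated change is a 2.1-fold lower number from compound 3 to compound 4 (0.32 log units; beyond the scatter). Compound 4 is expected at 1.1 mg/kg, with an estimated range of 0.4 mg/kg to 2.8 mg/kg.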

Compound 4, dose for half-maximal effect: 1.6 mg/kg
Compound 4: middle estimate off by 1.5-fold (0.16 log units), on the low side, and the stated range covers the measured number.
By their numbers in this assay, from the lowest: compounds 2, 4, 3 and 1 (each within the scatter of the next, the first and the last beyond it).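

In this assay the step of a 1.4-fold lower number from compound 3 to compound 4 (0.16 log units; within the scatter) shows that ethyl in place of hydrogen on a saturated chain carbon bound to an aromatic carbon, which turns methyl into propyl, stays within the scatter, unlike the lengthening of acetyl to propanoyl with its step of a 3.4-fold lower number from compound 1 to compound 2 (0.53 log units; beyond the scatter) beyond the scatter. Propyl also stays within the scatter of both carbonyl groups, with a step of a 1.7-fold higher number from compound 2 to compound 4 (0.23 log units; within the scatter) against propanoyl and one of a 2.0-fold lower number from compound 1 to compound 4 (0.30 log units; within the scatter) against acetyl, although these two compounds lie beyond the scatter of each other. No available measurement explains these results.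

The compounds shown leave open whether a longer chain such as butyl would move the number beyond the scatter. They also leave open how an amine or a carboxylic acid at the end of the chain would compare with propyl.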